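The source may hold more compounds than are shown below. What is called first, only, known or untested is meant among the compounds shown, and "the series" means these compounds.

Compound 1 `COc1cc(-n2c(-c3ccc(Cl)cc3)cn(C(C)=O)c2=O)cc(OC)c1OC`: > 50000 nM, a limit.
Compound 2 `COc1cc(-n2c(-c3ccc(F)cc3F)cn(C(C)=O)c2=O)cc(OC)c1OC`: > 50000 nM, a limit.

Both entries come from a functional assay on K562 cells (Homo sapiens) for cytotoxicity, read by MTT assay, with a stated time of 48 h (on this read-out lower numbers stand for stronger inhibition and higher numbers for weaker inhibition), and neither is a number. Compound 2 stands with compound 1 at the limit of > 50000 nM in this assay, at which 2 of the 2 values shown sit, so it offers only a limit as a starting point.

Compound 3 `COc1ccc(-c2cn(C(C)=O)c(=O)n2-c2cc(OC)c(OC)c(OC)c2)cc1OC` differs from compound 2 by 3,4-dimethoxyphenyl in place of 2,4-difluorophenyl on an aromatic carbon. Among the measured compounds shown here, the same aromatic carbon changed in the only measured step that bears on this one, a step that the two limits leave unreadable from compound 1 to compound 2. For the measured compounds named here, that step gives no size to carry over, and it shows no compound with a number in this assay. The expectation is therefore a weak one: inhibition should stay feeble, close to the limit, with only a modest shift toward stronger inhibition left open. The estimated change is an at least 1.4-fold lower number from compound 2 to compound 3 (0.15 log units; that floor lies within the scatter). For compound 3 the expected value is 35000 nM, with an estimated range of 5000 nM to 80000 nM.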

Compound 3, half-maximal inhibitory concentration: 43400 nM
The estimate for compound 3 lay 1.2-fold (0.09 log units) below the measured number; measured number inside the range.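

Among the compounds shown here, with 3,4-dimethoxyphenyl on this aromatic carbon of the five-membered aromatic ring, compound 3 gives 43400 nM in this assay, the first actual number at this position. The swap from 2,4-difluorophenyl gives an at least 1.1-fold lower number from compound 2 to compound 3 (0.06 log units; that floor lies within the scatter), and the swap from 4-chlorophenyl gives an at least 1.1-fold lower number from compound 1 to compound 3 (0.06 log units; that floor lies within the scatter), so neither step establishes a real gain in inhibition, and a number at this level remains weak. Most of this small set still rests on a limit rather than a number: the limit of > 50000 nM in this assay, at which 2 of the 3 values shown sit.

As far as these compounds go, whether an amine or a carboxylic acid on the phenyl ring at this carbon would move the number clearly beyond the scatter remains open. So does the part played by the acetyl group, which all three compounds carry, and whether a hydrogen or a longer chain in its place would change the reading.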